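Three inactive analogues and a 2-fluoro-4-nitrophenyl variant

The source may report more compounds than this note shows. Statements on the series, on what has been measured and on what is new or still open speak of the compounds shown alone.

compound 1, `CC(C)[C@H](NC(=O)COc1cccc2ccccc12)C(=O)N[C@@H](CC(=O)O)C(=O)COc1ccc(C(N)=O)cc1`, gives only a limit in a functional assay on Jurkat cells (Homo sapiens); on this read-out higher numbers stand for weaker inhibition and lower numbers for stronger inhibition: > 100000 nM
compound 2, `CC(C)[C@H](NC(=O)COc1cccc2ccccc12)C(=O)N[C@@H](CC(=O)O)C(=O)COc1ccccc1F`, gives only a limit in this assay: > 100000 nM
compound 3, `CC(C)[C@H](NC(=O)COc1cccc2ccccc12)C(=O)N[C@@H](CC(=O)O)C(=O)COc1ccc(F)c(F)c1`, gives only a limit in this assay: > 100000 nM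

Compound 3 therefore stands at a limit, not at a number, and the same holds for compound 1 and compound 2 (the limit of > 100000 nM in this assay, at which 3 of the 3 values shown sit). The step from compound 2 to compound 3, which exchanges the aryl group on the oxygen on a saturated carbon, cannot be read: a step that the two limits leave unreadable from compound 2 to compound 3. The same is true of the steps from compound 1: a step that the two limits leave unreadable from compound 1 to compound 2 and a step that the two limits leave unreadable from compound 1 to compound 3.

Compound 4, `CC(C)[C@H](NC(=O)COc1cccc2ccccc12)C(=O)N[C@@H](CC(=O)O)C(=O)COc1ccc([N+](=O)[O-])cc1F`, differs from compound 3 in one place: 2-fluoro-4-nitrophenyl in place of 3,4-difluorophenyl on an oxygen on a saturated carbon. The three exchanges of the aryl group that have been measured all left the read-out at the limit, so no direction and no size can be drawn from them. Compound 4 is accordingly expected to remain at or near that limit in this assay, with an expected step that the limit leaves unreadable from compound 3 to compound 4. The estimate for compound 4 is 150000 nM, with a range from 40000 nM to 600000 nM, and most likely only a limit will be reported.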

Compound 4, half-maximal inhibitory concentration: 30300 nM
The estimate for compound 4 lay 5.0-fold (0.69 log units) above the measured number; measured number below the stated range.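

Within the data shown here, the aryl group on the oxygen on a saturated carbon can move the read-out in this assay after all: compound 4 gives 30300 nM, a number where none of the earlier compounds gave one. The other three compounds remain at a limit, not a number: the limit of > 100000 nM in this assay, at which 3 of the 4 values shown sit.

Among these compounds, measured against those limits, the change appears as an at least 3.3-fold lower number from compound 3 to compound 4 (0.51 log units; beyond the scatter) and as an at least 3.3-fold lower number from compound 1 to compound 4 (0.51 log units; beyond the scatter), while the narrowest comparison, with nitro in place of hydrogen on an aromatic carbon as the only exchange, is an at least 3.3-fold lower number from compound 2 to compound 4 (0.51 log units; beyond the scatter).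

As far as these compounds go, the steps among compound 1, compound 2 and compound 3 cannot be read, and the full size of each step to compound 4 stays open, since only its lower bound is known. The compounds shown also leave open whether the nitro group is specifically required, or whether a nitrile or a trifluoromethyl group in its place would likewise bring the read-out below the limit.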